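The compounds below may be only part of what the source reports. "The series", "measured", "known", "first", "only" and "open" are said of these compounds alone.

Compound 1 `Cn1ccc(N2C[C@H](CN)OC2=O)c1` gives 10 nM in an assay for inhibition of Amine oxidase [flavin-containing] A (Bos taurus), read by fluorescence, with a stated time of 30 min; on this read-out higher numbers stand for weaker inhibition and lower numbers for stronger inhibition. Its ethyl analogue, compound 2 `CCn1ccc(N2C[C@H](CN)OC2=O)c1`, gives 130 nM in this assay; the change methyl in place of hydrogen on a saturated chain carbon bound to an aromatic nitrogen produced a 13-fold higher number from compound 1 to compound 2 (1.11 log units; beyond the scatter). Compound 3 `CNC[C@H]1CN(c2ccn(C)c2)C(=O)O1` differs from compound 1 by methyl in place of hydrogen on an amine nitrogen. In this assay compound 3 gives 7 nM, a shift of a 1.4-fold lower number from compound 1 to compound 3 (0.15 log units; within the scatter). Compound 4 `CCn1ccc(N2C[C@H](CNC)OC2=O)c1` carries both changes and is not yet measured; it differs from compound 3 by methyl in place of hydrogen on a saturated chain carbon bound to an aromatic nitrogen, the same change as from compound 1 to compound 2, at the same place. Because a 13-fold higher number from compound 1 to compound 2 (1.11 log units; beyond the scatter) was large and well beyond the scatter, compound 4 is expected to show a similar weakening, so that from compound 3 to compound 4 the step is estimated as a 13-fold higher number from compound 3 to compound 4 (1.11 log units; beyond the scatter). Compound 4 is accordingly expected to come in near 90 nM, most likely between 30 nM and 300 nM.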

Compound 4, inhibition constant: 80 nM
For compound 4 the middle estimate is 1.1-fold (0.05 log units) above the measured one; measured number inside the range.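

In this assay, methyl in place of hydrogen on a saturated chain carbon bound to an aromatic nitrogen gave an 11-fold higher number from compound 3 to compound 4 (1.06 log units; beyond the scatter), and this step carried from one core to the other with no difference beyond the scatter: the same change on two cores in this assay, a 13-fold higher number (1.11 log units; beyond the scatter) from compound 1 to compound 2 and an 11-fold higher number (1.06 log units; beyond the scatter) from compound 3 to compound 4, 1.1-fold (0.06 log units) apart, within the scatter of two such steps. Methyl in place of hydrogen on an amine nitrogen gave a 1.6-fold lower number from compound 2 to compound 4 (0.21 log units; within the scatter), and it likewise held its size on both cores: the same change on two cores in this assay, a 1.4-fold lower number (0.15 log units; within the scatter) from compound 1 to compound 3 and a 1.6-fold lower number (0.21 log units; within the scatter) from compound 2 to compound 4, 1.1-fold (0.06 log units) apart, within the scatter of two such steps. This shows that each change transferred between these cores in this one assay, but it does not show why, or that either change would transfer to any other core.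

The compounds shown leave open how a propyl group or a longer chain on the aromatic nitrogen would read. They also leave open how a dimethylamine in place of the amine would read.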